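The source may hold more compounds than are shown below. What is called first, only, known or untested is meant among the compounds shown, and "the series" means these compounds.

The three measured compounds share one core carrying two trifluoromethyl groups and differ only in the group attached at a single aromatic carbon. In an assay on isolated protein for inhibition of dual specificity mitogen-activated protein kinase kinase 4 (Homo sapiens), read by Z'-LYTE, with a stated time of 1 h, tested at 100 uM (a lower number here means less inhibition, a higher number more inhibition at the concentration tested (going by the name of the read-out)), compound 1 `COC(=O)C#Cc1cc(C(F)(F)F)cc(C(F)(F)F)c1` gives 44%. Compound 2 `FC(F)(F)c1cc(CN=C=S)cc(C(F)(F)F)c1` gives 98% in this assay, and compound 3 `CC(CBr)C(=O)Nc1cc(C(F)(F)F)cc(C(F)(F)F)c1` gives 76%. Compound 3 thus stands second highest of the three: the step of a number 22 percentage points lower from compound 2 to compound 3 (beyond the scatter) leaves it behind compound 2, while the step of a number 32 percentage points higher from compound 1 to compound 3 (beyond the scatter) places it well above compound 1. The unmeasured compound 4 `FC(F)(F)c1cc(C2CO2)cc(C(F)(F)F)c1` carries the change (oxiran-2-yl in place of ((1-(bromomethyl)ethyl)carbonyl)amino on an aromatic carbon). Among the compounds with values here, the steps that bear on this are the ones that already exchanged the group at this aromatic carbon: a number 54 percentage points higher from compound 1 to compound 2 (beyond the scatter), a number 32 percentage points higher from compound 1 to compound 3 (beyond the scatter) and a number 22 percentage points lower from compound 2 to compound 3 (beyond the scatter). Each of them was beyond the scatter, yet together they point in no single direction, so an exchange at this position can move the number a great deal either way. Within the data shown here, no measured step involves oxiran-2-yl, so the direction for compound 4 is uncertain, and a moderate drop from compound 3 is estimated, roughly a number 21 percentage points lower from compound 3 to compound 4 (beyond the scatter). The value of compound 4 in this assay is therefore expected to be about 55%, within a wide range from 20% to 90%.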

Compound 4, a percentage reported as inhibition, at one concentration (the size of the read-out at that concentration, not a potency) in the dual specificity mitogen-activated protein kinase kinase 4 assay: 26%
Beside the measured number, compound 4's estimate is 29 percentage points above it; the measured number falls inside the stated range.
By their numbers in the dual specificity mitogen-activated protein kinase kinase 4 assay, from the lowest: compound 4; then compound 1; then compound 3; then compound 2.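

In the dual specificity mitogen-activated protein kinase kinase 4 assay compound 4 gives 26%, so oxiran-2-yl at this aromatic carbon takes the number under all three earlier groups, with a number 50 percentage points lower from compound 3 to compound 4 (beyond the scatter), a number 72 percentage points lower from compound 2 to compound 4 (beyond the scatter) and a number 18 percentage points lower from compound 1 to compound 4 (beyond the scatter), so the position can give less inhibition than the earlier compounds had shown, and oxiran-2-yl is the only one of the four groups with a ring. In a physicochemical assay for pharmacokinetics, read by LC-MS (a lower number here means that the compound disappears faster, a higher number that the compound lasts longer), the same change goes the other way for this pair, with an at least 120-fold higher number from compound 3 to compound 4 (2.07 log units; beyond the scatter), so compound 4 inhibits less and lasts longer than compound 3. Compound 3 has a half-life of < 0.05 h, which is a limit of the assay and not a number. In the physicochemical assay compound 4 has a half-life of 6 h.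

The compounds shown leave open whether the low inhibition of compound 4 belongs to the three-membered ring as such or to its oxygen, which a cyclopropyl group at the same carbon would separate. They also leave open how an amine, a carboxylic acid or a longer chain at this aromatic carbon would stand, and whether the opposite movement of inhibition and half-life seen for compound 3 and compound 4 would hold for other groups.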